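Swapping Phenyl for Cyclopropyl on a Ring Amide Nitrogen

This account rests on a few compounds, and the source may have more. Where it says the series, first, only, none or still open, it means among the compounds named here.

Compound 1, with the structure `O=C(O)c1cc(-c2cccc(COc3ccc4c(c3)CN(c3ccccc3)C4=O)c2)ccc1Cl`, was tested in an ADME assay on a cell-free system (plasma, Rattus norvegicus), with a stated time of 60 min (on this read-out higher numbers stand for a more stable compound and lower numbers for a less stable compound), where compound 1 gives 100%. Two close relatives were measured alongside it. Compound 2, `O=C(O)c1cc(-c2cccc(COc3ccc4c(c3)CN(CC3CC3)C4=O)c2)ccc1Cl`, gives 100% in this assay, and compound 3, `O=C(O)c1cc(-c2cccc(COc3ccc4c(c3)CCN(C3CCCC3)C4=O)c2)ccc1Cl`, gives 100%. On these numbers compound 1 stands level with both companions; the nearest and the furthest of them sit at the same reading, within the usual scatter of the method.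

One of the measured steps touches the very position that matters here: no change at the digits printed from compound 1 to compound 2 (within the scatter). That step replaced the phenyl on the ring amide nitrogen with cyclopropylmethyl and left the reading unmoved.

Compound 4, `O=C(O)c1cc(-c2cccc(COc3ccc4c(c3)CN(C3CC3)C4=O)c2)ccc1Cl`, has not yet been measured. Compared with compound 1 its change is cyclopropyl in place of phenyl on an amide-type nitrogen in a ring. This is a smaller group placed on the same nitrogen that the measured step altered without effect, so nothing in the available numbers points to a shift. For compound 4 the expected step is therefore no change at the digits printed from compound 1 to compound 4 (within the scatter), none beyond the scatter. The estimate for compound 4 in this assay is 100%, with a range from 90% to 100%.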

Compound 4, percent of the compound remaining: 100%
Estimate against measurement, compound 4: no gap at the digits printed; measured number inside the range.
By their numbers in this assay, from the lowest: compounds 1, 2, 3 and 4 (each within the scatter of the next).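

The swap to cyclopropyl on the amide-type nitrogen in a ring reads as no change at the digits printed from compound 1 to compound 4 (within the scatter) in this assay, and the swap of cyclopropylmethyl for cyclopropyl reads as no change at the digits printed from compound 2 to compound 4 (within the scatter) on the same nitrogen. The earlier step showed only that one replacement of phenyl left this reading unmoved, whereas this nitrogen has now carried phenyl, cyclopropylmethyl and cyclopropyl on the same core with no difference in how much compound remains. Within this small set, then, a six-membered aromatic ring and a three-membered non-aromatic ring of carbon are interchangeable at this position for this read-out, and no measurement available here explains why the reading holds.

On these data alone, all of these groups are built of carbon only, so it remains open whether a group that plasma might act on differently, such as an ester or a chain ending in an amine, would give the same reading on this nitrogen. As far as these compounds go, it is also open whether this flat result carries over to any other read-out, since a stable reading here says nothing about how the compounds behave elsewhere.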